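The source may report more compounds than this note shows. Statements on the series, on what has been measured and on what is new or still open speak of the compounds shown alone.

Measured compounds:
compound 1, `O=c1[nH]cc(S(=O)(=O)Nc2ccccc2-c2cn(-c3ccc(F)cc3)nn2)c(=O)[nH]1`, 6390 nM
compound 2, `O=c1[nH]cc(S(=O)(=O)Nc2ccccc2-c2cn(-c3ccccc3Cl)nn2)c(=O)[nH]1`, 2740 nM
compound 3, `O=c1[nH]cc(S(=O)(=O)Nc2cccc(-c3cn(-c4ccc(F)cc4)nn3)c2)c(=O)[nH]1`, which gives only a limit of the assay, > 20000 nM

All three were tested in a functional assay on A549 cells (Homo sapiens) for antiproliferative activity, read by MTT assay, with a stated time of 24 h; a higher number here means a weaker inhibitor, a lower number a stronger inhibitor. Compound 2 differs from compound 1 by a single change, (2-chlorophenyl in place of 4-fluorophenyl on an aromatic nitrogen), and that change brought a 2.3-fold lower number from compound 1 to compound 2 (0.37 log units; beyond the scatter). Compound 3 shares its atoms with compound 1 but has them joined differently; the difference between the two cores is not broken down here. For compound 3 the assay reports only a limit, (the limit of > 20000 nM in this assay, at which 1 of the 3 values shown sits).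

Compound 4, `O=c1[nH]cc(S(=O)(=O)Nc2cccc(-c3cn(-c4ccccc4Cl)nn3)c2)c(=O)[nH]1`, has not yet been measured. It differs from compound 3 by 2-chlorophenyl in place of 4-fluorophenyl on an aromatic nitrogen, the same change that separates compound 1 from compound 2. The step from compound 3 to compound 4 is expected to be about as large as the earlier one, an at least 1.5-fold lower number from compound 3 to compound 4 (0.18 log units; that floor lies within the scatter), resting on a 2.3-fold lower number from compound 1 to compound 2 (0.37 log units; beyond the scatter). Since compound 3 itself has only a limit, the starting point is uncertain. Compound 4 is expected to give 13000 nM, with a likely range from 5000 nM to 40000 nM.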

Compound 4, half-maximal inhibitory concentration: 2730 nM
Compound 4: the middle estimate sits 4.8-fold (0.68 log units) above what was measured, and the stated range ends above it.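

In this assay, 2-chlorophenyl in place of 4-fluorophenyl on the aromatic nitrogen gave an at least 7.3-fold lower number from compound 3 to compound 4 (0.86 log units; beyond the scatter), the same direction as on the core of compound 1. The direction carried from one core to the other, but the size did not stay fixed: the same change on two cores in this assay, a 2.3-fold lower number (0.37 log units; beyond the scatter) from compound 1 to compound 2 and an at least 7.3-fold lower number (0.86 log units; beyond the scatter) from compound 3 to compound 4, at least 3.1-fold (0.49 log units) apart, beyond the scatter of two such steps. Compound 3 has only a limit and not a number, so the second step has a floor, and its true size and the reason for the gap remain unknown: the limit of > 20000 nM in this assay, at which 1 of the 4 values shown sits.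

The compounds shown leave open how a plain phenyl, a 4-chlorophenyl or a 2-fluorophenyl group on that nitrogen would behave on either core. Such groups could separate the part played by the halogen from the part played by its place on the ring.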